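The source may hold more compounds than are shown below. What is called first, only, known or untested is meant among the compounds shown, and "the series" means these compounds.

Of the compounds shown here, three sharing one core have been tested in an in vitro functional assay on cells (blood brain barrier) for antagonist activity at advanced glycosylation end product-specific receptor (Mus musculus), read by fluorescence, tested at 10 uM; on this read-out higher numbers stand for more inhibition at the one concentration tested (going by the name of the read-out) and lower numbers for less inhibition. Compound 1, `CCCCc1sc(-c2ccc(OCC3CCCN(CC)C3)cc2)nc1-c1ccc(Oc2ccc(Cl)cc2)cc1`, gives 77.5% in this assay, the highest of the three numbers. Compound 3, `CCCCc1sc(-c2ccc(Oc3ccc(Cl)cc3)cc2)nc1-c1ccc(OCC2CCCN(CC)C2)cc1`, gives 68.3% in this assay; its number and that of compound 1 lie within the usual scatter of each other, so no order between them can be read. Compound 2, `CCCCc1nc(-c2ccc(Oc3ccc(Cl)cc3)cc2)sc1-c1ccc(OCCCN(CC)CC)cc1`, gives 63.5% in this assay, a number that sits below that of compound 1 by more than the scatter.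

The next compound, compound 4, `CCCCc1sc(-c2ccc(OCCCN3CCCCC3)cc2)nc1-c1ccc(Oc2ccc(Cl)cc2)cc1`, has the same atoms as compound 1 joined differently. The change is 2-(piperidin-1-yl)ethyl in place of 1-ethylpiperidin-3-yl on a saturated chain carbon bound to an oxygen on an aromatic ring. Within the data shown here, no pair among the three measured compounds differs in only one place, so no measured step shows what such a rearrangement does here. Compound 4 carries its nitrogen at the end of a chain, as compound 2 does, and compound 2 gives 63.5%, so a modest fall in inhibition is expected, with the step from compound 1 to compound 4 estimated at a number 10.5 percentage points lower from compound 1 to compound 4 (beyond the scatter), close to the edge of the scatter. On that basis compound 4 is expected to give about 67% in this assay, with a range from 54% to 80%.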

Compound 4, a percentage reported as inhibition, at one concentration (the size of the read-out at that concentration, not a potency): 64.3%
Compound 4: the middle estimate sits 2.7 percentage points above what was measured, within the range that was stated.
By their numbers in this assay, from the lowest: compounds 2, 4, 3 and 1 (each within the scatter of the next, the first and the last beyond it).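

Among these compounds, this is the first pair that differs in one place only, so it gives the first direct reading of a change on the saturated chain carbon bound to an oxygen on an aromatic ring. In this assay, putting 2-(piperidin-1-yl)ethyl in place of 1-ethylpiperidin-3-yl keeps the same atoms and one six-membered non-aromatic ring, yet gives a number 13.2 percentage points lower from compound 1 to compound 4 (beyond the scatter), so at this position the way the atoms are joined matters, and not only which atoms are present. Nothing available explains why the rearrangement lowers the number.

A single pair cannot separate the effect of attaching the chain through the ring nitrogen from that of losing the ethyl group on that nitrogen, and it cannot tell whether the same swap would act alike on the arrangement of the core seen in compound 3. Also open, on these data alone, is how a morpholine ring or a plain dimethylamino group at this place, or a longer chain leading to the piperidine, would read in this assay.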